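This account rests on a few compounds, and the source may have more. Where it says the series, first, only, none or still open, it means among the compounds named here.

Compound 1 `Cc1ccc(O)c(-c2nc(N[C@H]3CCNC3)c3ccccc3n2)c1`: 92 nM
Compound 2 `CC(C)c1ccc(O)c(-c2nc(N[C@H]3CCNC3)c3ccccc3n2)c1`: 1700 nM
Compound 3 `Oc1ccc(F)cc1-c1nc(N[C@H]2CCNC2)c2ccccc2n1`: 60 nM

In an assay on isolated protein for inhibition of serine/threonine-protein kinase Chk2 (Homo sapiens) (on this read-out higher numbers stand for weaker inhibition and lower numbers for stronger inhibition), compound 3 gives the lowest of the three numbers; compound 1 lies within the scatter of it, whereas a 28-fold lower number from compound 2 to compound 3 (1.45 log units; beyond the scatter). Compound 4 `CC(C)(O)[C@H]1C[C@H](Nc2nc(-c3cc(F)ccc3O)nc3ccccc23)CN1` differs from compound 3 by 1-hydroxy-1-methylethyl in place of hydrogen on a saturated ring carbon. Among the measured compounds shown here, no measured step bears directly on this change: an 18-fold higher number from compound 1 to compound 2 (1.27 log units; beyond the scatter) and a 1.5-fold lower number from compound 1 to compound 3 (0.19 log units; within the scatter) both vary the group on the aromatic carbon, and the pyrrolidin-3-yl is left untouched in all three measured compounds. The large swings recorded so far come from the aromatic carbon alone, and the five-membered non-aromatic ring has no record of its own. The step is therefore expected to stay within the scatter, with no change at the digits printed from compound 3 to compound 4 (within the scatter) as the estimated shift. Compound 4 is expected at 60 nM, between 20 nM and 200 nM.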

Compound 4, half-maximal inhibitory concentration: 460 nM
Estimate against measurement, compound 4: 7.7-fold (0.88 log units) below; the measured number lies above the stated range.
By their numbers in this assay, from the lowest: compounds 3 and 1 (each within the scatter of the next); then compound 4; then compound 2.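

In this assay, among the compounds shown here, this is the first record for the five-membered non-aromatic ring, and substitution there is not neutral: 1-hydroxy-1-methylethyl on the saturated ring carbon next to the ring nitrogen gives a 7.7-fold higher number from compound 3 to compound 4 (0.88 log units; beyond the scatter). Changes to the aromatic carbon are therefore not the only ones that move the number in this series. No available evidence accounts for the step.

The compounds shown leave open how a methyl, an aminomethyl or a carboxylic acid at this ring carbon would compare with 1-hydroxy-1-methylethyl. They also leave open how the opposite configuration at this carbon would read.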